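Trifluoromethyl for methoxy on the compound 3 aryl ring

This account rests on a few compounds, and the source may have more. Where it says the series, first, only, none or still open, it means among the compounds named here.

- compound 1 `Nc1ccc2oc(-c3cccc(C(F)(F)F)c3)c(O)c(=O)c2c1`: 8100 nM
- compound 2 `COc1c(-c2ccccc2)oc2ccc(N)cc2c1=O`: 126000 nM
- compound 3 `COc1cccc(-c2oc3ccc(N)cc3c(=O)c2OC)c1`: 251000 nM

In an ADME assay on MT4 cells (Homo sapiens) for cytotoxicity, read by MTT assay, with a stated time of 4 days (a higher number here means that more compound is tolerated, a lower number that less compound is tolerated), compound 3 gives 251000 nM, within the scatter of compound 2 and far above compound 1. The next compound, compound 4 `COc1c(-c2cccc(C(F)(F)F)c2)oc2ccc(N)cc2c1=O`, carries trifluoromethyl in place of methoxy on an aromatic carbon. Among the compounds with values here, only one measured step touches this change: a 2.0-fold higher number from compound 2 to compound 3 (0.30 log units; within the scatter). That step brought in methoxy in place of hydrogen, so removing methoxy alone is not expected to shift the number much. Within the data shown here, the trifluoromethyl group itself appears only in compound 1, at 8100 nM, but that compound also differs from compound 3 elsewhere, so no measured step isolates the group. The expectation is therefore a moderate move towards compound 1, not the whole gap. The expected change is a 4.2-fold lower number from compound 3 to compound 4 (0.62 log units; beyond the scatter). For compound 4 the estimated value is 60000 nM, with an expected range from 15000 nM to 200000 nM.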

Compound 4, half-maximal cytotoxic concentration: 73100 nM
The estimate for compound 4 lay 1.2-fold (0.09 log units) below the measured number; low and high end bracket the measured number.
By their numbers in this assay, from the lowest: compound 1; then compounds 4, 2 and 3 (each within the scatter of the next, the first and the last beyond it).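

In this assay, trifluoromethyl in place of methoxy on this aromatic carbon gives a 3.4-fold lower number from compound 3 to compound 4 (0.54 log units; beyond the scatter), while trifluoromethyl in place of hydrogen gives a 1.7-fold lower number from compound 2 to compound 4 (0.24 log units; within the scatter), so the trifluoromethyl compound cannot be told apart from the compound without a substituent on that ring. With the trifluoromethyl group held the same, methyl in place of hydrogen on the oxygen gives a 9.0-fold higher number from compound 1 to compound 4 (0.96 log units; beyond the scatter), which shows that trifluoromethyl alone does not bring the low number of compound 1. No measurement here gives a reason for either shift.

Going by these compounds, the oxygen step rests on this one pair, so it remains open whether it holds with methoxy or hydrogen on the aryl ring. Also open, on these data alone, is how a group such as a nitrile or a carboxylic acid would read on this aromatic carbon.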